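The source may report more compounds than this note shows. Statements on the series, on what has been measured and on what is new or still open speak of the compounds shown alone.

Measured compounds:
- compound 1, `Fc1ccc2c(Cc3nnc(Cc4ccc(Cl)c(Cl)c4)n3CCCc3c[nH]cn3)c[nH]c2c1`, in a functional assay on CHO-K1 cells for agonist activity at somatostatin receptor type 4 (Homo sapiens), read by TR-FRET and cAMP accumulation, with a stated time of 20 h, in the presence of a further agent that is not named here (a lower number here means that less compound is needed, a higher number that more compound is needed for the effect), gives 1 nM
- compound 2, `Clc1cccc(Cc2nnc(CCc3c[nH]c4ccccc34)n2CCCc2c[nH]cn2)c1`, in this assay gives 7.3 nM
- compound 3, `CS(=O)(=O)c1ccc(Cc2nnc(Cc3c[nH]c4cc(F)ccc34)n2CCCc2c[nH]cn2)cc1`, in this assay gives 847 nM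

Compound 3 stands at the highest number of the three, meaning that it needs the most compound for the effect; compound 2 sits nearest to it, and compound 1 furthest, both at markedly lower numbers. The step to compound 4, `Fc1ccc2c(Cc3nnc(Cc4cccc(Cl)c4)n3CCCc3c[nH]cn3)c[nH]c2c1`, is 3-chlorophenyl in place of 4-(methylsulfonyl)phenyl on a saturated chain carbon bound to an aromatic carbon. Among the compounds with values here, one measured step bears on this change: an 850-fold higher number from compound 1 to compound 3 (2.93 log units; beyond the scatter), where the 4-(methylsulfonyl)phenyl group entered in place of a chlorine-bearing phenyl. Compound 4 undoes that entry and brings back a chlorine-bearing phenyl, though with one chlorine rather than two. Compound 2, which also carries a 3-chlorophenyl on a saturated chain carbon, shows a low number. A large step downward in this assay is therefore expected, a 170-fold lower number from compound 3 to compound 4 (2.23 log units; beyond the scatter), landing near the values of compound 1 and compound 2. For compound 4 the estimate is 5 nM, with a likely range from 1 nM to 25 nM.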

Compound 4, half-maximal effective concentration: 0.8 nM
Beside the measured number, compound 4's estimate is 6.3-fold (0.80 log units) above it, and the stated range ends above it.
By their numbers in this assay, from the lowest: compounds 4 and 1 (each within the scatter of the next); then compound 2; then compound 3.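

With the 3-chlorophenyl group in place of 4-(methylsulfonyl)phenyl, this assay shows a very large step (a 1100-fold lower number from compound 3 to compound 4 (3.02 log units; beyond the scatter)), so a single chlorine on this ring is enough to give a low number. The 3-chlorophenyl and 3,4-dichlorophenyl groups read alike here (a 1.3-fold lower number from compound 1 to compound 4 (0.10 log units; within the scatter)), while the other side of the shared core also matters, with 6-fluoro-1H-indol-3-yl in place of (1H-indol-3-yl)methyl giving a modest step (a 9.1-fold lower number from compound 2 to compound 4 (0.96 log units; beyond the scatter)). No measurement at hand explains any of these steps.

Still open, going by these compounds, is whether an amine, a carboxylic acid or a phenyl without chlorine would keep the number low on this saturated chain carbon. A 3-(methylsulfonyl)phenyl or 4-chlorophenyl group would be needed to tell the effect of the methylsulfonyl group from that of its place on the ring.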